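Chain length at the amide linker of the shared core

The source may report more compounds than this note shows. Statements on the series, on what has been measured and on what is new or still open speak of the compounds shown alone.

Three members of the series have numbers in an assay on HEK293 cells for displacement of a labelled ligand from NPC1-like intracellular cholesterol transporter 1 (Homo sapiens); a lower number here means a stronger inhibitor, a higher number a weaker inhibitor. Compound 1 `CC(C)(C)OC(=O)N1CCN(C(=O)CN2CN(c3ccccc3)C3(CCN(C(=O)c4ccc(C5CCCCC5)cc4)CC3)C2=O)CC1` gives 3500 nM. Compound 2 `CC(C)(C)OC(=O)NCNC(=O)CN1CN(c2ccccc2)C2(CCN(C(=O)c3ccc(C4CCCCC4)cc3)CC2)C1=O` gives 1700 nM, the lowest of the three; compound 1 lies beyond the scatter above it, and compound 3 `CC(C)(C)OC(=O)NCC1CCN(C(=O)CN2CN(c3ccccc3)C3(CCN(C(=O)c4ccc(C(C)(C)C)cc4)CC3)C2=O)CC1`, with 4200 nM, lies further above still. Compound 4 `CC(C)(C)OC(=O)NCCCNC(=O)CN1CN(c2ccccc2)C2(CCN(C(=O)c3ccc(C4CCCCC4)cc3)CC2)C1=O` has not yet been measured. It differs from compound 2 in one place: 2-((tert-butoxycarbonyl)amino)ethyl in place of (tert-butoxycarbonyl)amino on a saturated chain carbon bound to an amide-type nitrogen. Among the compounds with values here, no pair of measured compounds differs in a single place, so the size of this step has no precedent. The step is expected to stay within the scatter, in either direction. Compound 4 is expected near 1500 nM, within 600 nM to 4000 nM. That estimate corresponds to a step of a 1.1-fold lower number from compound 2 to compound 4 (0.05 log units; within the scatter).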

Compound 4, half-maximal inhibitory concentration: 6000 nM
Compound 4: the middle estimate sits 4.0-fold (0.60 log units) below what was measured; the measured number lies above the stated range.
By their numbers in this assay, from the lowest: compound 2; then compounds 1, 3 and 4 (each within the scatter of the next).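

In this assay, within the data shown here, the change from (tert-butoxycarbonyl)amino to 2-((tert-butoxycarbonyl)amino)ethyl on a saturated chain carbon bound to an amide-type nitrogen gives a 3.5-fold higher number from compound 2 to compound 4 (0.55 log units; beyond the scatter) as the first single-place step. At this position, then, the longer chain comes with a weaker inhibitor, and the difference lies beyond the scatter. No available evidence bears on this step.

Open, from the compounds shown here alone, is what a free amine or a carboxylic acid would do at the chain end. Also open, going by these compounds, is whether a still longer chain would raise the number further.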